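Methyl to chloro on the aryl of compound 1

The source may hold more compounds than are shown below. What is called first, only, known or untested is meant among the compounds shown, and "the series" means these compounds.

In a functional assay on CCRF-CEM cells (Homo sapiens) for inhibition, read by cell counting, with a stated time of 3 days (a higher number here means a weaker inhibitor, a lower number a stronger inhibitor), compound 1 `C=C(Br)C(=O)Nc1cccc(-c2cn3nc(-c4ccc(C)cc4)sc3n2)c1` gives 1700 nM and stands as the lower of the two numbers recorded; compound 2 `Cc1ccc(-c2nn3cc(-c4cccc(N)c4)nc3s2)cc1` gives 5900 nM in this assay. Among the compounds with values here, the only measured step is a 3.5-fold higher number from compound 1 to compound 2 (0.54 log units; beyond the scatter), which concerns the nitrogen on the aromatic ring and does not touch the change under study. Compound 3 `C=C(Br)C(=O)Nc1cccc(-c2cn3nc(-c4ccc(Cl)cc4)sc3n2)c1` differs from compound 1 by chloro in place of methyl on an aromatic carbon. Within the data shown here, no measured step bears on this exchange, so no shift beyond the scatter is expected, and the estimated step is no change at the digits printed from compound 1 to compound 3 (within the scatter). Compound 3 is expected to give about 1700 nM in this assay, within 700 nM to 4000 nM.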

Compound 3, half-maximal inhibitory concentration: 3200 nM
Compound 3: middle estimate off by 1.9-fold (0.27 log units), on the low side; low and high end bracket the measured number.
By their numbers in this assay, from the lowest: compounds 1, 3 and 2 (each within the scatter of the next, the first and the last beyond it).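

Chloro in place of methyl on this aromatic carbon gives a 1.9-fold higher number from compound 1 to compound 3 (0.27 log units; within the scatter) in this assay, so at this position the assay does not separate the two groups. Within the data shown here, this is the first reading at the aryl end of the series, as the earlier step concerned only the nitrogen on the other aromatic ring. No evidence beyond these numbers bears on this result. Still open, from the compounds shown here alone, is whether a different group on this carbon, such as methoxy, an amine or a carboxylic acid, moves the number beyond the scatter.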